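The step from compound 2 to compound 4

The source may report more compounds than this note shows. Statements on the series, on what has been measured and on what is new or still open speak of the compounds shown alone.

Compound 2 `CCCNC(=O)c1sc2nc(-c3cccs3)cc(-c3ccccc3)c2c1N` has no measured number: in an assay for inhibition of 15-hydroxyprostaglandin dehydrogenase [NAD(+)] (Homo sapiens), read by fluorescence, with a stated time of 15 min, in the presence of a further agent that is not named here (a higher number here means a weaker inhibitor, a lower number a stronger inhibitor), compound 2 gives only a limit, > 7500 nM. This is the situation described by the limit of > 7500 nM in this assay, at which 1 of the 3 values shown sits. Compound 1 `CCCC[S+]([O-])c1sc2nc(-c3nccs3)cc(-c3ccc(CO)cc3)c2c1N` gives 2.5 nM in this assay, and compound 3 `CCCC[S+]([O-])c1sc2nc(-c3nccs3)cc(-c3ccc(CN)cc3)c2c1N` gives 11.5 nM. Going by the values given here, the single measured step, a 4.6-fold higher number from compound 1 to compound 3 (0.66 log units; beyond the scatter), concerns a different part of the molecule and does not bear on the change at hand. Compound 4 `CCCCCC[S+]([O-])c1sc2nc(-c3cccs3)cc(-c3ccccc3)c2c1N` differs from compound 2 by a group of 8 heavy atoms (6 carbon, 1 oxygen, 1 sulfur; no ring) in place of a group of 6 heavy atoms (4 carbon, 1 nitrogen, 1 oxygen; no ring), on an aromatic carbon. Among the compounds with values here, compounds 1 and 3 carry a related chain at this place and inhibit strongly, but they also differ from compound 4 elsewhere, so no measured step sets the size. Compound 4 is estimated at 30 nM, between 3 nM and 600 nM. The expected step, an at least 250-fold lower number from compound 2 to compound 4 (2.39 log units; beyond the scatter), is toward a stronger inhibitor.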

Compound 4, half-maximal inhibitory concentration: 18 nM
Compound 4: the middle estimate sits 1.7-fold (0.22 log units) above what was measured, and the stated range covers the measured number.
By their numbers in this assay, from the lowest: compound 1; then compounds 3 and 4 (each within the scatter of the next). At a limit, above all of these: compound 2.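

In this assay, going by these compounds alone, the change at this aromatic carbon, next to the ring sulfur, gives the first reading of this position: propylcarbamoyl gives way to the group of 8 heavy atoms, with an at least 410-fold lower number from compound 2 to compound 4 (2.61 log units; beyond the scatter). This single change separates an inhibitor in the range of compound 1 and compound 3 from a compound with no measured number. The size of the step is only a bound, as compound 2 stands at a limit: the limit of > 7500 nM in this assay, at which 1 of the 4 values shown sits.

On these data alone, it remains open how a shorter chain in the entering group, or a carboxylic acid or an amine at this carbon, would read. As far as these compounds go, it also remains open whether the step would keep its size on the core of compound 1.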